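Swapping benzyloxy for 4-chlorophenyl on the sulfonamide side chain

The source may report more compounds than this note shows. Statements on the series, on what has been measured and on what is new or still open speak of the compounds shown alone.

Measured compounds:
compound 1 `O=C1c2ccccc2N(COCc2ccccc2)S(=O)(=O)N1Cc1ccccc1`: > 122000 nM
compound 2 `O=C1c2ccccc2N(COCc2ccccc2)S(=O)(=O)N1COCc1ccccc1`: 130000 nM

In a functional assay on HEL cells (Homo sapiens) for inhibition (a higher number here means that more compound is tolerated, a lower number that less compound is tolerated), compound 1 reaches only the limit > 122000 nM, which is a bound of the measurement and not a number. Compound 2 gives 130000 nM in this assay. Among the measured compounds shown here, the only measured step, a step that the limit leaves unreadable from compound 1 to compound 2, cannot be sized because of the limit of > 122000 nM in this assay, at which 1 of the 2 values shown sits. Compound 3 `O=C1c2ccccc2N(Cc2ccc(Cl)cc2)S(=O)(=O)N1Cc1ccccc1` differs from compound 1 by 4-chlorophenyl in place of benzyloxy on a saturated chain carbon bound to a sulfonamide nitrogen in a ring. For the measured compounds named here, no measured step covers this exchange, and the one step that exists is unreadable, so it offers no guide to direction or size. With compound 1 sitting at the bound, the expectation for compound 3 is a result close to that bound, with an expected step of an at least 1.1-fold lower number from compound 1 to compound 3 (0.04 log units; that floor lies within the scatter) that stays within the usual scatter. The estimate for compound 3 in this assay is 110000 nM, with a range from 40000 nM to 250000 nM.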

Compound 3, half-maximal cytotoxic concentration: > 200000 nM
Compound 3 was reported as a limit (the forecaster's own chance of this, stated with the estimate: 50%); at least 1.8-fold (0.25 log units) between middle value and limit.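

In this assay compound 3 gives > 200000 nM, which is a limit and not a number. Among the compounds shown here, compound 1 also stands only at a limit, and no step between compound 1 and compound 3 can be read. From the compounds shown here alone, whether 4-chlorophenyl in place of benzyloxy changes the half-maximal cytotoxic concentration at all, and in which direction, stays open.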